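This account rests on a few compounds, and the source may have more. Where it says the series, first, only, none or still open, it means among the compounds named here.

The compounds here share one small core and differ only in the groups attached to it. Compound 1 `C=C1CN(C)N(c2ccc(Cl)cc2)C1=O` was tested in a functional assay on MCF7 cells (Homo sapiens) for inhibition, read by MTT assay, with a stated time of 48 h (on this read-out higher numbers stand for weaker inhibition and lower numbers for stronger inhibition), where compound 1 gives 45200 nM. Of the two numbers recorded so far this is the highest, which on this read-out marks it as the weaker of the two inhibitors. The other measured compound is compound 2 `C=C1C(=O)N(c2ccccc2)N(c2ccccc2)C1C`; in this assay compound 2 gives 12500 nM, a number that sits beyond the usual scatter from that of compound 1. Among the measured compounds shown here, no pair of measured compounds differs in just one place, so no measured step can guide the next change directly.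

The compound still to be tested is compound 3 `C=C1CN(C)N(c2ccccc2)C1=O`. It arises from compound 1 by hydrogen in place of chloro on an aromatic carbon. For the measured compounds named here, no measured step of this kind exists, so the size of the change is uncertain; the expectation is that a 1.3-fold higher number from compound 1 to compound 3 (0.12 log units; within the scatter) stays small, either within the scatter or a modest shift towards weaker inhibition. On this basis compound 3 is expected to give about 60000 nM in this assay, with a range estimated from 25000 nM to 150000 nM.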

Compound 3, half-maximal inhibitory concentration: 56000 nM
Estimate against measurement, compound 3: 1.1-fold (0.03 log units) above; low and high end bracket the measured number.
By their numbers in this assay, from the lowest: compound 2; then compounds 1 and 3 (each within the scatter of the next).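

Among the compounds shown here, the first measured step at this position is a 1.2-fold higher number from compound 1 to compound 3 (0.09 log units; within the scatter) in this assay, so the two compounds cannot be told apart in this assay. For this pair, then, the chloro group on an aromatic carbon of the six-membered aromatic ring can be exchanged for hydrogen without a shift beyond the scatter, which means the chlorine atom is not needed for the activity that compound 1 shows here. Nothing available explains why this exchange leaves the number within the scatter, as no supporting evidence bears on this result.

On these data alone, what a different group at this same place, such as a methoxy group, an amine or a carboxylic acid, would do remains open, since a single exchange of chloro for hydrogen cannot show how far this position tolerates change. Compound 2 differs from compound 1 and from compound 3 in more than one place, so steps to it cannot be read, and what sets its number apart remains unresolved.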